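One more chloro on the higher-numbered compound

The source may hold more compounds than are shown below. What is called first, only, known or untested is meant among the compounds shown, and "the series" means these compounds.

In a functional assay on HepG2 cells (Homo sapiens) for cytotoxicity, with a stated time of 24 h (on this read-out higher numbers stand for weaker inhibition and lower numbers for stronger inhibition), compound 1 (`COc1cc(Cl)ccc1C(=O)Nc1cc(Cl)c(Cl)cc1O`) gives 11500 nM and compound 2 (`COc1ccc(Cl)cc1C(=O)Nc1ccc(Cl)cc1O`) gives 51300 nM as the higher of the two numbers, which makes compound 2 the weaker inhibitor, by a gap beyond the scatter. Compound 3 (`COc1ccc(Cl)cc1C(=O)Nc1cc(Cl)c(Cl)cc1O`) comes from compound 2 by a single change: chloro in place of hydrogen on an aromatic carbon, ortho to a chloro group, meta to a large group and para to a hydroxy group. Among the compounds with values here, no measured pair isolates this change, so its size cannot be read directly. Within the data shown here, the only lower number available is that of compound 1 at 11500 nM in this assay and a downward step beyond the scatter is therefore expected. The estimated step is a 3.4-fold lower number from compound 2 to compound 3 (0.53 log units; beyond the scatter) on this read-out. For compound 3 the expected value is 15000 nM within an estimated range of 6000 nM to 35000 nM in this assay once measured.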

Compound 3, half-maximal inhibitory concentration: 2980 nM
Compound 3: middle estimate off by 5.0-fold (0.70 log units), on the high side; the measured number lies below the stated range.
By their numbers in this assay, from the lowest: compound 3; then compound 1; then compound 2.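

In this assay, within the data shown here, the change appears as a 17-fold lower number from compound 2 to compound 3 (1.24 log units; beyond the scatter) and gives the first direct reading of this position, since no earlier pair isolated it. A single chloro in place of hydrogen on this aromatic carbon, ortho to a chloro group, meta to a large group and para to a hydroxy group, thus accounts for a large move toward stronger inhibition. Nothing available explains why a change of one heavy atom has a step of this size.

As far as these compounds go, whether a fluoro, a methyl or an amine at this same position would give a step of similar size or direction remains open. From the compounds shown here alone, it is also open whether the chloro would have the same effect on the core of compound 1.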